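Methoxy in place of bromo on the shared core

The source may hold more compounds than are shown below. What is called first, only, known or untested is meant among the compounds shown, and "the series" means these compounds.

Compound 1 `COc1ccc(-c2nn(-c3ccccc3)cc2-c2nc3cc(F)ccc3[nH]2)cc1` gives 1740 nM
Compound 2 `COc1ccc(-c2nn(-c3ccccc3)cc2-c2nc3cc(Br)ccc3[nH]2)cc1` gives 1060 nM

In a functional assay on HeLa cells (Homo sapiens) for antiproliferative activity, read by MTT assay, with a stated time of 48 h (on this read-out lower numbers stand for stronger inhibition and higher numbers for weaker inhibition), compound 2 (value 1060 nM) stands within the scatter of compound 1 (value 1740 nM), so the numbers do not separate the two. Compound 3 `COc1ccc(-c2nn(-c3ccccc3)cc2-c2nc3cc(OC)ccc3[nH]2)cc1` carries methoxy in place of bromo on an aromatic carbon. For the measured compounds named here, only one measured step bears on this place, bromo in place of fluoro (a 1.6-fold lower number from compound 1 to compound 2 (0.22 log units; within the scatter)), and it lies within the scatter. Going by the values given here, no measured compound holds methoxy there, so this single step is a thin guide. On that basis no step beyond the scatter is expected in this assay, in either direction. The estimated change is small (a 1.3-fold higher number from compound 2 to compound 3 (0.12 log units; within the scatter)). For compound 3 the expected value is 1400 nM (estimated range 550 nM to 3500 nM).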

Compound 3, half-maximal inhibitory concentration: 1140 nM
The estimate for compound 3 lay 1.2-fold (0.09 log units) above the measured number, within the range that was stated.
By their numbers in this assay, from the lowest: compounds 2, 3 and 1 (each within the scatter of the next).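

In this assay, methoxy in place of bromo on an aromatic carbon brings a 1.1-fold higher number from compound 2 to compound 3 (0.03 log units; within the scatter), and methoxy in place of fluoro at the same place brings a 1.5-fold lower number from compound 1 to compound 3 (0.18 log units; within the scatter). The earlier pair compared only two halogens, whereas methoxy is a group of another kind, with a hydrogen-bond acceptor that bromo lacks, and still the numbers do not separate compound 1, compound 2 and compound 3 at this position. No evidence accompanies these numbers that could say what lies behind this result.

The compounds shown leave open whether an amine, a carboxylic acid or a longer chain at this place would stand apart from these three. They also leave open whether any group here can move the number beyond the scatter, in either direction.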